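Lengthening the Hexyl Chain of Compound 2

A few compounds are considered here, and "the series" means these few. Any claim that something is new, unique, unknown or untested is made for them only; others in the source may bear on it.

Compound 2 `CCCCCCc1cn([C@@H]2O[C@H](CO)[C@@H](O)[C@H]2O)nn1` carries a hexyl group on an aromatic carbon of the shared core. In a functional assay on MOLT-4 cells (Homo sapiens) (a lower number here means a stronger inhibitor, a higher number a weaker inhibitor), compound 2 gives > 200000 nM, which is a limit of the assay and not a number. Its closest relative, compound 1 `NC(=O)c1cn([C@@H]2O[C@H](CO)[C@@H](O)[C@H]2O)nn1`, has a carbamoyl group where compound 2 has the hexyl. In this assay compound 1 gives > 200000 nM, again a limit rather than a number. The step that the two limits leave unreadable from compound 1 to compound 2 therefore cannot be read. Within the data shown here, the only evidence on the measured steps is the limit of > 200000 nM in this assay, at which 2 of the 2 values shown sit.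

Compound 3 `CCCCCCCCc1cn([C@@H]2O[C@H](CO)[C@@H](O)[C@H]2O)nn1` differs from compound 2 by ethyl in place of hydrogen on a saturated chain carbon, six bonds along the chain from an aromatic carbon. Among the measured compounds shown here, no measured step of readable size bears on this change, since a step that the two limits leave unreadable from compound 1 to compound 2 is hidden by the two limits. The step expected here, a number no higher from compound 2 to compound 3 (the limit leaves the size open), should be none beyond the scatter, with a further limit the most likely outcome. The estimate for compound 3 in this assay is 200000 nM, with a range from 50000 nM to 500000 nM.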

Compound 3, half-maximal inhibitory concentration: 50000 nM
For compound 3 the middle estimate is 4.0-fold (0.60 log units) above the measured one; the range from low to high includes it.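

On the hexyl chain, ethyl in place of hydrogen on a saturated chain carbon, six bonds along the chain from an aromatic carbon, gives an at least 4.0-fold lower number from compound 2 to compound 3 (0.60 log units; beyond the scatter) in this assay. Among these compounds, with this change, compound 3 gives 50000 nM, the first true number and the first sign that this chain position can alter the result in this assay. Compound 2 stands at a limit and not at a number, so the step gives only a minimum size, and much of the series still sits at that one limit: the limit of > 200000 nM in this assay, at which 2 of the 3 values shown sit.

As far as these compounds go, a single readable step cannot show a trend with chain length, so it stays open whether a longer chain would lower the number further. From the compounds shown here alone, what an amine or a carboxylic acid would do on this chain also stays open.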